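Swapping an aryl for a benzyl on a fused heteroaromatic core

This account rests on a few compounds, and the source may have more. Where it says the series, first, only, none or still open, it means among the compounds named here.

Three compounds have been examined in a functional assay on HeLa cells (Homo sapiens) for inhibition, read by cell counting, with a stated time of 4 days; a lower number here means a stronger inhibitor, a higher number a weaker inhibitor. Compound 1 `COc1ccc(-c2nn3cc(-c4cccc(N)c4)nc3s2)cc1OC` gives 26000 nM. Compound 2 `C=C(Br)C(=O)Nc1cccc(-c2cn3nc(-c4ccc(C)cc4)sc3n2)c1` gives 2000 nM, and compound 3 `C=C(Br)C(=O)Nc1cccc(-c2cn3c(-c4ccccc4)csc3n2)c1` gives 3400 nM. Among these three numbers compound 2 gives the lowest, but its gap to compound 3 lies within the scatter, while its gap to compound 1 lies beyond it. Compound 4 `C=C(Br)C(=O)Nc1cccc(-c2cn3nc(Cc4ccccc4)sc3n2)c1` differs from compound 2 in one place: benzyl in place of 4-methylphenyl on an aromatic carbon. Within the data shown here, no measured pair in this set reports such a change, so only an expectation can be offered. A small step in this assay toward a weaker inhibitor is expected, possibly no larger than the scatter, so compound 4 is estimated at 3500 nM with a range from 1200 nM to 10000 nM, a step of a 1.8-fold higher number from compound 2 to compound 4 (0.24 log units; within the scatter).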

Compound 4, half-maximal inhibitory concentration: 4500 nM
For compound 4 the middle estimate is 1.3-fold (0.11 log units) below the measured one; low and high end bracket the measured number.
By their numbers in this assay, from the lowest: compounds 2, 3 and 4 (each within the scatter of the next, the first and the last beyond it); then compound 1.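

In this assay, among these compounds, the swap of 4-methylphenyl for benzyl on this aromatic carbon gives a 2.3-fold higher number from compound 2 to compound 4 (0.35 log units; beyond the scatter) and is the first single-place change in the set. The two groups have the same heavy atoms and the same carbon-only aromatic ring, so joining those atoms differently is enough to produce a modest change at this position. Nothing available explains this step.

A single step cannot show how far this position tolerates other groups. As far as these compounds go, how a 2-phenylethyl chain, an amine or a carboxylic acid on this carbon would compare remains open.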